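Swapping a Trimethoxyphenyl for Naphthyl in a Dienone Series

A few compounds are considered here, and "the series" means these few. Any claim that something is new, unique, unknown or untested is made for them only; others in the source may bear on it.

Four compounds share a common core, and each carries a different aryl group on the dienone chain. Compound 1 `COc1ccccc1/C=C/C(=O)/C=C/c1ccc(OCc2cn(CCCOc3cc(=O)oc4ccccc34)nn2)c(OC)c1` is "not active" (no number reported) in a functional assay on PC-3 cells (Homo sapiens) for inhibition, read by sulforhodamine B assay, with a stated time of 48 h, tested at 50 uM; on this read-out higher numbers stand for more inhibition of growth at the one concentration tested and lower numbers for less inhibition of growth. Compound 3 `COc1cc(/C=C/C(=O)/C=C/c2cc(OC)c(OC)c(OC)c2)ccc1OCc1cn(CCCCCOc2cc(=O)oc3ccccc23)nn1` is also "not active" (no number reported) in this assay. Among the compounds with values here, compound 2 `COc1cc(/C=C/C(=O)/C=C/c2cc(OC)c(OC)c(OC)c2)ccc1OCc1cn(CCOc2cc(=O)oc3ccccc23)nn1` gives 22% in this assay, the only number among the three, so it stands as the sole measured point of reference. Compound 4 `COc1cc(/C=C/C(=O)/C=C/c2cccc3ccccc23)ccc1OCc1cn(CCOc2cc(=O)oc3ccccc23)nn1` differs from compound 2 by one change: naphthalen-1-yl in place of 3,4,5-trimethoxyphenyl on a double-bonded chain carbon bound to a double-bonded chain carbon. Within the data shown here, no measured pair shows what this change does, so the expectation rests on compound 2 alone. The step from compound 2 to compound 4 in this assay is expected to be small, near or slightly below the scatter, at a number 7 percentage points lower from compound 2 to compound 4 (within the scatter). Compound 4 is therefore estimated at 15%, within 0% to 35%.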

Compound 4, percent growth inhibition at one concentration: 20%
Estimate against measurement, compound 4: 5 percentage points below, within the range that was stated.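

Placing naphthalen-1-yl where 3,4,5-trimethoxyphenyl stood gives, in this assay, a number 2 percentage points lower from compound 2 to compound 4 (within the scatter), so the two compounds cannot be told apart. At this position on the chain, the methoxy groups can therefore be lost and a second aromatic ring gained with no readable change in growth inhibition at the one concentration tested. Nothing shown here offers an explanation for this result.

From the compounds shown here alone, whether an unsubstituted phenyl, or a pyridine ring, would behave the same way at this position remains open. So does whether a carboxylic acid or an amine on the aryl group would shift growth inhibition beyond the usual scatter.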